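Azido-cytidine epimer pair: tolerated concentration in cell viability

The compounds below may be only part of what the source reports. "The series", "measured", "known", "first", "only" and "open" are said of these compounds alone.

Working notes on a short series of azido-bearing cytidine nucleoside analogues, with the cell-viability read-out an ADME assay on WST1 cells (Homo sapiens) for cytotoxicity, read by WST assay (a lower number here means that less compound is tolerated, a higher number that more compound is tolerated), as the single measure in hand. Within the data shown here, compound 1 `[N-]=[N+]=N[C@]1(CO)O[C@@H](n2ccc(N)nc2=O)[C@H](O)[C@H]1O` is the only member with any recorded result. In this assay compound 1 gives < 100000 nM, and this is a limit of the assay rather than a measured number. The standing of compound 1 on the values shown is therefore described only by the limit of < 100000 nM in this assay, at which 1 of the 3 values shown sits, and no single number places it. Compound 2 `[N-]=[N+]=N[C@@]1(CO)C[C@@H](O)[C@H](n2ccc(N)nc2=O)O1` has "not determined" (no result reported) in this assay. Compound 3 `C[C@@]1(O)[C@H](n2ccc(N)nc2=O)O[C@@](CO)(N=[N+]=[N-])[C@H]1O` likewise has "not determined" (no result reported) in this assay. Among the measured compounds shown here, no pair of measured compounds differs in one place, so no measured step exists to compare against.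

The open question is compound 4 `[N-]=[N+]=N[C@]1(CO)O[C@@H](n2ccc(N)nc2=O)[C@H](O)[C@@H]1O`. The change from compound 1 is the two compounds have the same atoms and bonds; at least one stereo element is drawn with a configuration in one of them and without one in the other: 1 of 5 stereo elements differ; a stereocentre at a saturated ring carbon is drawn R in compound 1 and S in compound 4. With a single limit as the only anchor, the inversion at one saturated ring carbon is expected to give a step from compound 1 to compound 4 of about a step that the limit leaves unreadable from compound 1 to compound 4 in this assay, that is, none beyond the usual scatter. Compound 4 is accordingly estimated at 60000 nM in this assay, within a range of 20000 nM to 150000 nM, and the outcome may again be reported only as a limit.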

Compound 4, half-maximal cytotoxic concentration: < 2000000 nM
Compound 4 ended at the assay's limit; the forecaster's own chance of this, stated with the estimate: 65%; the middle value is on the limit's open side.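

In this assay compound 4 gives < 2000000 nM, which is a limit of the assay and not a number. Among these compounds, compound 1 also stands only as a limit, and no step between compound 1 and compound 4 can be read. The compounds shown leave open whether inverting that saturated ring carbon changes the tolerated concentration at all.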